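Azetidine Ketone Replaces the Methoxymethyl Arm

The compounds below may be only part of what the source reports. "The series", "measured", "known", "first", "only" and "open" are said of these compounds alone.

Three compounds that share one core have been measured in an assay for inhibition of Amine oxidase [flavin-containing] A (Homo sapiens); a lower number here means a stronger inhibitor, a higher number a weaker inhibitor:

Compound 1 `CN1CCN(CCCC(=O)c2ccc(-c3ccc(N4C[C@H](Cn5ccnn5)OC4=O)cc3F)cn2)CC1` gives 10500 nM
Compound 2 `COCc1ccc(-c2ccc(N3C[C@H](Cn4ccnn4)OC3=O)cc2F)cn1` gives 1700 nM
Compound 3 `O=C1O[C@@H](Cn2ccnn2)CN1c1ccc(-c2ccc(C(O)C3CNC3)nc2)c(F)c1` gives 58000 nM

Compound 2 stands lowest of the three, and both gaps to the others lie beyond the scatter: the step of a 6.2-fold lower number from compound 1 to compound 2 (0.79 log units; beyond the scatter) and the step of a 34-fold higher number from compound 2 to compound 3 (1.53 log units; beyond the scatter). Compound 4 `O=C(c1ccc(-c2ccc(N3C[C@H](Cn4ccnn4)OC3=O)cc2F)cn1)C1CNC1` has not yet been measured. Relative to compound 2 the change is (azetidin-3-yl)carbonyl in place of methoxymethyl on an aromatic carbon, on the six-membered aromatic ring with one nitrogen, next to the ring nitrogen and para to a large group.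

For the measured compounds named here, two measured steps bear on this. Compound 3 carries the same four-membered ring, attached through a hydroxymethyl rather than a carbonyl, and its step of a 34-fold higher number from compound 2 to compound 3 (1.53 log units; beyond the scatter) was large. Compound 1 carries a carbonyl at the same position with a longer chain, and its step of a 5.5-fold higher number from compound 1 to compound 3 (0.74 log units; beyond the scatter) shows a modest gap. Compound 4, with the ring on a carbonyl, would be expected to land between those two, well above compound 2.

Compound 4 is therefore estimated at 20000 nM, within a range from 5000 nM to 80000 nM. That estimate corresponds to an expected step of a 12-fold higher number from compound 2 to compound 4 (1.07 log units; beyond the scatter).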

Compound 4, inhibition constant: 4500 nM
For compound 4 the middle estimate is 4.4-fold (0.65 log units) above the measured one; the measured number lies below the stated range.
By their numbers in this assay, from the lowest: compound 2; then compound 4; then compound 1; then compound 3.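

In this assay, putting (azetidin-3-yl)carbonyl on this aromatic carbon, next to the ring nitrogen, in place of methoxymethyl gives a 2.6-fold higher number from compound 2 to compound 4 (0.42 log units; beyond the scatter) as a modest loss, and compound 2 remains the strongest inhibitor of the four. The carbon joining the azetidine to the aromatic ring matters much more: with the four-membered ring kept, (azetidin-3-yl)carbonyl in place of (azetidin-3-yl)(hydroxy)methyl gives a 13-fold lower number from compound 3 to compound 4 (1.11 log units; beyond the scatter) as a large gain, so the carbonyl form does not share the weakness of the hydroxy form. With the carbonyl held fixed, azetidin-3-yl in place of 3-(4-methylpiperazin-1-yl)propyl gives a 2.3-fold lower number from compound 1 to compound 4 (0.37 log units; beyond the scatter) as a smaller gain, showing that the group on the carbonyl also changes the number, though less than the carbonyl-to-hydroxy change does.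

No measurement shown accounts for any of these steps. The wide gap between the carbonyl and hydroxy forms remains unexplained. Also open, on these data alone, is how a simple methyl ketone, or a piperidine ring on the carbonyl in place of the azetidine, would compare with compound 2 and compound 4.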